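A few compounds are considered here, and "the series" means these few. Any claim that something is new, unique, unknown or untested is made for them only; others in the source may bear on it.

Compound 3 `CC1(C)CCCN(CCCCC2CCCc3ccccc32)C1` shows the lowest number of the three compounds measured in an assay on cell membranes for binding affinity to Sigma non-opioid intracellular receptor 1 (Rattus norvegicus), read by radioligand binding; on this read-out higher numbers stand for weaker inhibition and lower numbers for stronger inhibition. Compound 1 `CC1(C)CCCN(CCCC2=CCc3ccccc32)C1` gives 0.99 nM in this assay, a value within the scatter of compound 3, which gives 0.69 nM. For the measured compounds named here, compound 2 `COc1cccc2c1CCC2CCCCN1CCCC(C)(C)C1`, the only measured compound carrying a methoxy group, gives 9.3 nM in this assay, a number beyond the scatter above compound 3. Compound 4 `COc1cccc2c1CCCC2CCCCN1CCCC(C)(C)C1` differs from compound 3 by methoxy in place of hydrogen on an aromatic carbon. Going by the values given here, no single step in this assay isolates this change, so the direction rests on what compound 2 shows with 9.3 nM. A weakening beyond the scatter is expected, with the step from compound 3 to compound 4 estimated at a 5.8-fold higher number from compound 3 to compound 4 (0.76 log units; beyond the scatter). Compound 4 is therefore expected to give about 4 nM in this assay, within a range of 1.2 nM to 14 nM.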

Compound 4, half-maximal inhibitory concentration: 978 nM
For compound 4 the middle estimate is 240-fold (2.39 log units) below the measured one; the measured number lies above the stated range.
By their numbers in this assay, from the lowest: compounds 3 and 1 (each within the scatter of the next); then compound 2; then compound 4.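

For the compounds shown here, with methoxy in place of hydrogen on an aromatic carbon, ortho to a fused ring and meta to a fused ring, this assay gives a 1400-fold higher number from compound 3 to compound 4 (3.15 log units; beyond the scatter), a large weakening and the first step here to isolate a single change. It shows that, on this core, this one substitution at this position alone can cost most of the inhibition. Nothing available explains the size of this loss. On these data alone, whether a fluorine or a hydroxyl on the same aromatic carbon would weaken inhibition as strongly stays open. So does the effect of methoxy on the other aromatic carbons.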